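Swapping chloro for trifluoromethyl on the aryl ring of compound 3

This account rests on a few compounds, and the source may have more. Where it says the series, first, only, none or still open, it means among the compounds named here.

Measured so far:
compound 1, `CC[C@H](NC(C)=O)c1cc(Cl)ccc1C1CCN(C(=O)[C@@H]2CN(C(C)(C)C)C[C@H]2c2ccc(Cl)cc2Cl)CC1`, 156 nM
compound 2, `CC[C@H](NC(C)=O)c1cc(Cl)ccc1C1CCN(C(=O)[C@@H]2CN(C(C)(C)C)C[C@H]2c2ccc(F)cc2Cl)CC1`, 215 nM
compound 3, `CC[C@H](NC(C)=O)c1cc(Cl)ccc1C1CCN(C(=O)[C@@H]2CN(C(C)(C)C)C[C@H]2c2ccc(Cl)cc2F)CC1`, 2.8 nM

In a functional assay on CHO cells for agonist activity at Melanocortin receptor 4 (Homo sapiens), read by cAMP accumulation (on this read-out lower numbers stand for an effect already at smaller amounts and higher numbers for an effect only at larger amounts of compound), compound 3 holds the lowest number of the three; the gaps a 56-fold lower number from compound 1 to compound 3 (1.75 log units; beyond the scatter) and a 77-fold lower number from compound 2 to compound 3 (1.89 log units; beyond the scatter) are both beyond the scatter, so compound 3 is the most potent compound measured here. Compound 4, `CC[C@H](NC(C)=O)c1cc(Cl)ccc1C1CCN(C(=O)[C@@H]2CN(C(C)(C)C)C[C@H]2c2ccc(C(F)(F)F)cc2F)CC1`, differs from compound 3 by trifluoromethyl in place of chloro on an aromatic carbon. Going by the values given here, no measured step swaps chloro for trifluoromethyl. The nearest comparison is a 1.4-fold higher number from compound 1 to compound 2 (0.14 log units; within the scatter), a change at the same ring carbon that stayed within the scatter, whereas a 56-fold lower number from compound 1 to compound 3 (1.75 log units; beyond the scatter) shows that the ring is sensitive at the other carbon. The group now entering is new, so a modest shift is expected in either direction, and compound 4 is estimated at 5 nM (range 1.5 nM to 20 nM), which means an expected step of a 1.8-fold higher number from compound 3 to compound 4 (0.25 log units; within the scatter).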

Compound 4, half-maximal effective concentration: 88.8 nM
Beside the measured number, compound 4's estimate is 18-fold (1.25 log units) below it, outside the stated range (above it).
By their numbers in this assay, from the lowest: compound 3; then compounds 4, 1 and 2 (each within the scatter of the next, the first and the last beyond it).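

At this aromatic carbon, an earlier swap of chloro for fluoro moved the number only within the scatter, but with the fluoro group kept on the ring, trifluoromethyl gives a 32-fold higher number from compound 3 to compound 4 (1.50 log units; beyond the scatter), so the carbon is not indifferent to the group it carries. Most of the advantage of compound 3 is gone: a 2.4-fold lower number from compound 2 to compound 4 (0.38 log units; beyond the scatter) remains a modest step, and a 1.8-fold lower number from compound 1 to compound 4 (0.24 log units; within the scatter) stays within the scatter. Nothing given here explains the loss.

Still open, on these data alone, is how a methyl, a methoxy or a nitrile would read at this carbon with the fluoro group kept.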